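A few compounds are considered here, and "the series" means these few. Any claim that something is new, unique, unknown or untested is made for them only; others in the source may bear on it.

Measured so far in a functional assay on HepG2 cells (Homo sapiens) for antiproliferative activity, read by MTT assay, with a stated time of 48 h; on this read-out higher numbers stand for weaker inhibition and lower numbers for stronger inhibition:
compound 1 `COc1ccc(-c2ccc3c(c2)C(=O)C(=O)N3Cc2ccc(Cl)c(Cl)c2)cc1`: 990 nM
compound 2 `COc1ccc(-c2ccc3c(c2)C(=O)C(=O)N3Cc2ccc(Cl)cc2)cc1`: 250 nM
compound 3 `COc1ccc(CN2C(=O)C(=O)c3cc(-c4ccc(OC)cc4)ccc32)cc1`: 50 nM

Compound 3 stands lowest of the three, and its steps to both others lie beyond the scatter. The next change leads to compound 4 `COc1ccc(-c2ccc3c(c2)C(=O)C(=O)N3Cc2cccc(OC)c2)cc1`, which has the same atoms joined differently: 3-methoxyphenyl in place of 4-methoxyphenyl on a saturated chain carbon bound to an amide-type nitrogen in a ring. In words, 3-methoxyphenyl stands in place of 4-methoxyphenyl on a saturated chain carbon bound to an amide-type nitrogen in a ring.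

No measured step moves a methoxy group, so the size of this change is not shown directly. The nearest evidence comes from three steps that alter the same group. These are a 4.0-fold lower number from compound 1 to compound 2 (0.60 log units; beyond the scatter), a 5.0-fold lower number from compound 2 to compound 3 (0.70 log units; beyond the scatter) and a 20-fold lower number from compound 1 to compound 3 (1.30 log units; beyond the scatter), so the group has moved the number by modest to large amounts. The expected direction in this assay is a higher number, meaning weaker inhibition, as compound 3 holds the lowest value at 50 nM and the other two groups both give higher numbers. A modest change is expected, with the expected step being a 2.4-fold higher number from compound 3 to compound 4 (0.38 log units; beyond the scatter). The range stays wide, and a result within the scatter of compound 3 would not be surprising. For compound 4 the estimated value is 120 nM, with an expected range from 40 nM to 400 nM.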

Compound 4, half-maximal inhibitory concentration: 700 nM
Compound 4: the middle estimate sits 5.8-fold (0.77 log units) below what was measured; measured number outside the range, above it.
By their numbers in this assay, from the lowest: compound 3; then compound 2; then compounds 4 and 1 (each within the scatter of the next).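

In this assay, shifting the methoxy alone, from 4-methoxybenzyl to 3-methoxybenzyl, gives a 14-fold higher number from compound 3 to compound 4 (1.15 log units; beyond the scatter), so this place on the saturated chain carbon responds to where the methoxy stands and not merely to its presence. The 3-methoxyphenyl group also compares poorly with 4-chlorophenyl, at a 2.8-fold higher number from compound 2 to compound 4 (0.45 log units; beyond the scatter), and is not separated from 3,4-dichlorophenyl, at a 1.4-fold lower number from compound 1 to compound 4 (0.15 log units; within the scatter); among these four compounds the lowest number therefore belongs to 4-methoxyphenyl in particular, not to methoxy-bearing groups in general. No measurement at hand accounts for the gap between the two methoxy placements.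

Still open, going by these compounds, is whether the low number of compound 3 at 50 nM is specific to methoxy, which 4-ethoxyphenyl, 4-hydroxyphenyl or 4-aminophenyl at the same place would test. Also open, on these data alone, is how 2-methoxyphenyl would read, and whether 3-chlorophenyl against compound 2 would show a shift of the same kind, which would tell whether this sensitivity extends beyond the methoxy group.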